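This account rests on a few compounds, and the source may have more. Where it says the series, first, only, none or still open, it means among the compounds named here.

Measured in a toxicity assay on HepG2 cells (Homo sapiens) for inhibition, read by CellTiter-Glo, with a stated time of 48 h; on this read-out higher numbers stand for weaker inhibition and lower numbers for stronger inhibition:
Compound 1 `COc1ccc2nc(C)cc(OCC(=O)Nc3cc(C)cc(C)c3)c2c1` gives 20000 nM.
Compound 2 `COc1ccc2nc(C)cc(OCC(=O)Nc3cccc(C)c3)c2c1` gives 39800 nM.
Compound 3 `COc1ccc2nc(C)cc(OCC(=O)Nc3cc(C)ccc3C)c2c1` gives > 100000 nM, which is a limit of the assay and not a number.

Compound 3 therefore stands only as a limit on the numbers shown. Both measured steps into it end at that limit: an at least 5.0-fold higher number from compound 1 to compound 3 (0.69 log units; beyond the scatter) and an at least 2.5-fold higher number from compound 2 to compound 3 (0.40 log units; beyond the scatter). Between the two numbered compounds the step is a 2.0-fold higher number from compound 1 to compound 2 (0.30 log units; within the scatter). The limit of > 100000 nM in this assay, at which 1 of the 3 values shown sits, leaves the true position of compound 3 open, so the size of any step out of it cannot be read from the data.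

Compound 4 `COc1cccc(NC(=O)COc2cc(C)nc3ccc(OC)cc23)c1` is the compound to be measured in this assay. It differs from compound 3 in one place: 3-methoxyphenyl in place of 2,5-dimethylphenyl on an amide-type nitrogen. Compound 2, with its 3-methylphenyl on the same nitrogen, is the nearest comparison among the measured compounds. Given the limit of > 100000 nM in this assay, at which 1 of the 3 values shown sits, at which compound 3 sits, the expected step of an at least 2.0-fold lower number from compound 3 to compound 4 (0.30 log units; that floor lies within the scatter) is toward a lower number but of uncertain size. Taking compound 2 as the guide, compound 4 is expected to give 50000 nM, with a range from 15000 nM to 100000 nM, and it may again fall at the limit.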

Compound 4, half-maximal inhibitory concentration: > 100000 nM
Compound 4 gave a limit, no number; the forecaster's own chance of this, stated with the estimate: 35%; middle value at least 2.0-fold (0.30 log units) from the limit.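

In this assay, compound 4 ends at a limit of the assay and not a number, as compound 3 does, so the step between them cannot be read: the limit of > 100000 nM in this assay, at which 2 of the 4 values shown sit.

Methoxy in place of methyl on an aromatic carbon gives an at least 2.5-fold higher number from compound 2 to compound 4 (0.40 log units; beyond the scatter), and 3-methoxyphenyl in place of 3,5-dimethylphenyl on the amide-type nitrogen gives an at least 5.0-fold higher number from compound 1 to compound 4 (0.69 log units; beyond the scatter). A move to the limit on this nitrogen is therefore no longer tied to 2,5-dimethylphenyl alone: it now also comes with a group that carries oxygen, while compound 1 and compound 2 keep measured numbers.

As far as these compounds go, how far compound 3 and compound 4 lie beyond the limit, and in what order, stays open. Also open, from the compounds shown here alone, is whether an amine or a carboxylic acid in place of the methoxy of compound 4 would return a measured number.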